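Cytotoxicity notes: aryl for methyl on the piperazine nitrogen

The source may hold more compounds than are shown below. What is called first, only, known or untested is meant among the compounds shown, and "the series" means these compounds.

Measured compounds:
- compound 1 `COc1cc(Cc2cnc(/N=C3\C(=O)N(CN4CCN(C)CC4)c4ccc(Cl)cc43)nc2N)cc(OC)c1OC`: 88 ug/mL
- compound 2 `CCN(CC)CN1C(=O)/C(=N\c2ncc(Cc3cc(OC)c(OC)c(OC)c3)c(N)n2)c2cc(Cl)ccc21`: 98.4 ug/mL

Within the data shown here, in an ADME assay on CCRF-CEM cells (Homo sapiens) for cytotoxicity, read by MTT assay, with a stated time of 5 days (a lower number here means that less compound is tolerated, a higher number that more compound is tolerated), compound 1 gives 88 ug/mL, the lowest of the two numbers so far; the nearest is compound 2, with a 1.1-fold higher number from compound 1 to compound 2 (0.05 log units; within the scatter), a step that stays within the scatter. That step swaps diethylamino for 4-methylpiperazin-1-yl on the saturated chain carbon bound to the amide-type nitrogen, so it touches the same end of the molecule as the change considered here, but not the same atom.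

Compound 3 `COc1cccc(N2CCN(CN3C(=O)/C(=N\c4ncc(Cc5cc(OC)c(OC)c(OC)c5)c(N)n4)c4cc(Cl)ccc43)CC2)c1` has not yet been measured in this assay. It differs from compound 1 by 3-methoxyphenyl in place of methyl on an amine nitrogen in a ring. Among the measured compounds shown here, the only step that bears on it is the one from compound 1 to compound 2, which was small; the present change is larger in atom count and adds an aromatic ring and an acceptor, for which no measured comparison exists. The expectation is therefore a number near compound 1, with a 1.3-fold lower number from compound 1 to compound 3 (0.10 log units; within the scatter) not clearly beyond the scatter, if anything toward a lower number. Compound 3 is estimated at 70 ug/mL, with a range from 35 ug/mL to 140 ug/mL.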

Compound 3, half-maximal cytotoxic concentration: 23.3 ug/mL
Compound 3: middle estimate off by 3.0-fold (0.48 log units), on the high side; the whole stated range lies above it.
By their numbers in this assay, from the lowest: compound 3; then compounds 1 and 2 (each within the scatter of the next).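

In this assay, the change from methyl to 3-methoxyphenyl on the amine nitrogen of the six-membered non-aromatic ring gives a 3.8-fold lower number from compound 1 to compound 3 (0.58 log units; beyond the scatter), so less compound is tolerated after this change. This shows that the series can respond to a change at this end of the molecule, which the earlier comparison did not reveal: a 1.1-fold higher number from compound 1 to compound 2 (0.05 log units; within the scatter), a change that replaced the whole 4-methylpiperazin-1-yl group with diethylamino. Nothing measured here explains the shift, and this single step cannot assign it to the aromatic ring or to the methoxy group within the entering substituent.

The compounds shown do not separate those two parts, and plain phenyl on the same nitrogen would be the direct comparison with compound 3, while benzyl would test whether a carbon spacer between that nitrogen and the aromatic ring changes the outcome. Among these compounds, also open is whether the step reflects a general effect of large groups on this nitrogen or something particular to 3-methoxyphenyl, as only this one aryl group is available for comparison.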